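Series notes: appending a pyrrolidinylpropyl chain to compound 2

This account rests on a few compounds, and the source may have more. Where it says the series, first, only, none or still open, it means among the compounds named here.

Compound 2 `CCc1n[nH]c2ncnc(N3CCN(c4cc(Cl)ccc4C)CC3)c12` is the reference point. In an assay for inhibition of ribosomal protein S6 kinase beta-1 variant D18H,T412E (Homo sapiens), read by a luciferase reporter and chemiluminescence, with a stated time of 3 h (a lower number here means a stronger inhibitor, a higher number a weaker inhibitor), compound 2 gives 6 nM; compound 1 `Cc1ccc(Cl)cc1N1CCN(c2ncnc3[nH]nc(C)c23)CC1` gives 9 nM in this assay, and the step of a 1.5-fold lower number from compound 1 to compound 2 (0.18 log units; within the scatter) leaves the two within the scatter of each other, so neither stands apart. Compound 3 `CCc1n[nH]c2ncnc(N3CCN(c4cc(Cl)cc(CCCN5CCCC5)c4C)CC3)c12` differs from compound 2 by 3-(pyrrolidin-1-yl)propyl in place of hydrogen on an aromatic carbon. Among the measured compounds shown here, the only measured step, a 1.5-fold lower number from compound 1 to compound 2 (0.18 log units; within the scatter), alters a saturated chain carbon bound to an aromatic carbon and says nothing about a substituent entering the six-membered aromatic ring of carbon only; no measured pair adds any group there. For the measured compounds named here, with no comparable step in hand, the working expectation for compound 3 is a change of no more than the scatter in this assay, with the range set wide. Compound 3 is estimated at 7 nM (range 2 nM to 30 nM), corresponding to an expected step of a 1.2-fold higher number from compound 2 to compound 3 (0.07 log units; within the scatter).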

Compound 3, half-maximal inhibitory concentration: 2 nM
Beside the measured number, compound 3's estimate is 3.5-fold (0.54 log units) above it; low and high end bracket the measured number.
By their numbers in this assay, from the lowest: compound 3; then compounds 2 and 1 (each within the scatter of the next).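

On the six-membered aromatic ring of carbon only, the position ortho to the methyl group and meta to the chloro group tolerates 3-(pyrrolidin-1-yl)propyl in this assay, and the change gives a 3.0-fold lower number from compound 2 to compound 3 (0.48 log units; beyond the scatter). Among the compounds shown here, the earlier step altered only a saturated chain carbon bound to an aromatic carbon, so this is the first measured change on this ring and the first step beyond the scatter. No measurement at hand accounts for the stronger inhibition.

The compounds shown leave open whether the gain requires the pyrrolidine ring or the full propyl chain; a shorter chain, a morpholine ring or a simple dimethylamine at the chain end would separate these. Also open, as far as these compounds go, is whether the same group has a similar effect on compound 1.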